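Aryl in Place of Propyl on the Amide Nitrogen

The source may report more compounds than this note shows. Statements on the series, on what has been measured and on what is new or still open speak of the compounds shown alone.

In a functional assay on HeLa cells (Homo sapiens) for cytotoxicity, read by MTT assay, with a stated time of 24 h (on this read-out lower numbers stand for stronger inhibition and higher numbers for weaker inhibition), compound 3 `C=CC1=C(C(=O)NCCC)C(c2ccc(OC)cc2)OC1` gives 14000 nM. Compound 2 `C=CC1=C(C(=O)NC2CCCCC2)C(c2ccc(OC)cc2)OC1` gives 24800 nM in this assay, and the step of a 1.8-fold lower number from compound 2 to compound 3 (0.25 log units; within the scatter) lies within the scatter, so the two stand side by side. Compound 1 `C=CC1=C(C(=O)Nc2ccc(C)cc2)C(c2ccc(F)cc2)OC1` reports only a limit in this assay, > 100000 nM (the limit of > 100000 nM in this assay, at which 1 of the 3 values shown sits). Compound 4 `C=CC1=C(C(=O)Nc2ccc(C)cc2)C(c2ccc(OC)cc2)OC1` differs from compound 3 by 4-methylphenyl in place of propyl on an amide-type nitrogen. Among the compounds with values here, no measured step covers this change directly; the step from cyclohexyl to propyl was small, while compound 1, which carries the same 4-methylphenyl on the amide nitrogen, shows only a limit. Compound 4 is therefore expected to give a higher number, an estimated 60000 nM with a range from 15000 nM to 200000 nM. The expected step is a 4.3-fold higher number from compound 3 to compound 4 (0.63 log units; beyond the scatter).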

Compound 4, half-maximal inhibitory concentration: > 100000 nM
Compound 4 was reported as a limit; the forecaster's own chance of this, stated with the estimate: 45%; middle value at least 1.6-fold (0.22 log units) from the limit.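

Replacing propyl or cyclohexyl on the amide nitrogen with 4-methylphenyl, with the rest of the structure unchanged, gives an at least 7.1-fold higher number from compound 3 to compound 4 (0.85 log units; beyond the scatter) and an at least 4.0-fold higher number from compound 2 to compound 4 (0.60 log units; beyond the scatter), whereas the step between the two non-aromatic groups stayed within the scatter. The step between compound 1 and compound 4, methoxy in place of fluoro on an aromatic carbon, cannot be read, as both values are limits: the limit of > 100000 nM in this assay, at which 2 of the 4 values shown sit.

The compounds shown leave open whether this rise goes with the aromatic ring itself or with its methyl group. They also leave open how an unsubstituted phenyl, a benzyl or a longer chain on the amide nitrogen would read.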